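Chloro to methyl swap on a shared core: working notes

The source may report more compounds than this note shows. Statements on the series, on what has been measured and on what is new or still open speak of the compounds shown alone.

Measured so far, in a functional assay on SW480 cells (Homo sapiens) for cytotoxicity, read by MTT assay, with a stated time of 72 h; a higher number here means a weaker inhibitor, a lower number a stronger inhibitor:
Compound 1 `Cc1cc(C)nc(SCc2cc(=O)c3cc(Cl)ccc3o2)n1` gives > 25000 nM, a limit of the assay.
Compound 2 `O=c1cc(CSc2nc3ccccc3s2)oc2ccc(Cl)cc12` gives > 25000 nM, also a limit.
Compound 3 `Cc1ccc2oc(CSc3nc(C)cc(C)n3)cc(=O)c2c1` gives > 25000 nM, again a limit.

Compound 3 differs from compound 1 by methyl in place of chloro on an aromatic carbon. The step that the two limits leave unreadable from compound 1 to compound 3 cannot be read, since both compounds sit at the limit of > 25000 nM in this assay, at which 3 of the 3 values shown sit. How the core of compound 2 differs from that of compound 1 is not broken down here.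

Compound 4 `Cc1ccc2oc(CSc3nc4ccccc4s3)cc(=O)c2c1` is not yet measured. It differs from compound 2 by methyl in place of chloro on an aromatic carbon, the same change at the same place as from compound 1 to compound 3. The expected step that the limit leaves unreadable from compound 2 to compound 4 is near nothing, because compound 2 sits at the limit of > 25000 nM in this assay, at which 3 of the 3 values shown sit, and the measured pair offers no readable trend. Compound 4 is expected to give about 35000 nM in this assay, most likely again reported as a limit, within 12000 nM to 100000 nM.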

Compound 4, half-maximal inhibitory concentration: > 25000 nM
Compound 4 gave a limit, no number; the forecaster's own chance of this, stated with the estimate: 80%; the middle value does not contradict the limit.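

No step can be read between compound 2 and compound 4, because both stand at a limit, not a number: the limit of > 25000 nM in this assay, at which 4 of the 4 values shown sit.
The compounds shown leave open whether methyl in place of chloro on an aromatic carbon changes activity on either core.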